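Adding a methyl next to the amine on a longer linker

This account rests on a few compounds, and the source may have more. Where it says the series, first, only, none or still open, it means among the compounds named here.

Compound 1 `COc1ccccc1CN(C)CCCn1sc2cc(OC)c(OC)cc2c1=O` and compound 2 `CCN(CCCn1sc2cc(OC)c(OC)cc2c1=O)Cc1ccccc1OC` share one core; compound 3 `COc1ccccc1CN(C)CCCCn1sc2cc(OC)c(OC)cc2c1=O` and the unmeasured compound 4 `CCN(CCCCn1sc2cc(OC)c(OC)cc2c1=O)Cc1ccccc1OC` share another, and the difference between the two cores is not broken down here. In an assay on isolated protein for inhibition of Amine oxidase [flavin-containing] A (Homo sapiens), read by fluorescence, with a stated time of 30 min (on this read-out higher numbers stand for weaker inhibition and lower numbers for stronger inhibition), compound 1 gives 9400 nM and compound 2 gives 15500 nM. The change between them is methyl in place of hydrogen on a saturated chain carbon bound to an amine nitrogen, and it made the step of a 1.6-fold higher number from compound 1 to compound 2 (0.22 log units; within the scatter). Compound 3 gives 7100 nM in this assay. Compound 4 carries the same change on its own core, (methyl in place of hydrogen on a saturated chain carbon bound to an amine nitrogen), the second time this change appears among these four compounds. The expected step for compound 4 is a 1.4-fold higher number from compound 3 to compound 4 (0.15 log units; within the scatter), which rests on the step that the same change made a 1.6-fold higher number from compound 1 to compound 2 (0.22 log units; within the scatter) on the other core, a step that stayed inside the usual scatter. Among the measured compounds shown here, with only one earlier example of this change, the expectation is held loosely. Compound 4 is therefore estimated at 10000 nM in this assay, most likely between 5000 nM and 20000 nM.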

Compound 4, half-maximal inhibitory concentration: 9600 nM
Beside the measured number, compound 4's estimate is 1.0-fold (0.02 log units) above it; the range from low to high includes it.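

In this assay, the new step is a 1.4-fold higher number from compound 3 to compound 4 (0.13 log units; within the scatter), so methyl in place of hydrogen on a saturated chain carbon bound to an amine nitrogen again leaves the number inside the usual scatter of repeated measurements. Set beside the earlier step, the result on the second core cannot be told apart from the result on the first: the same change on two cores in this assay, a 1.6-fold higher number (0.22 log units; within the scatter) from compound 1 to compound 2 and a 1.4-fold higher number (0.13 log units; within the scatter) from compound 3 to compound 4, 1.2-fold (0.09 log units) apart, within the scatter of two such steps. This shows that the change carries over between these two cores without a clear effect on either, but it does not show whether a small real effect lies hidden in the scatter, or that the change would act alike on any other core.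

From the compounds shown here alone, it remains open whether a larger group at the same place, such as a propyl chain, would move the number beyond the scatter. Also open, going by these compounds, is how the change would behave with a still longer chain in the core, or with a cyclic amine such as piperidine in place of this open-chain amine.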